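The source may report more compounds than this note shows. Statements on the series, on what has been measured and on what is new or still open speak of the compounds shown alone.

Measured so far:
compound 1 `Cc1ccc(/C=C/c2nnc(-c3ccc4c(c3)OCCO4)o2)cc1` — 45200 nM
compound 2 `Cc1ccccc1/C=C/c1nnc(-c2ccc3c(c2)OCCO3)o1` — 40500 nM

Both compounds were tested in a functional assay on HUVEC cells (Homo sapiens) for antiproliferative activity, read by MTT assay, with a stated time of 48 h; on this read-out higher numbers stand for weaker inhibition and lower numbers for stronger inhibition. Compound 1 stands at the highest of the two numbers, and its nearest neighbour is compound 2: the step of a 1.1-fold lower number from compound 1 to compound 2 (0.05 log units; within the scatter) falls within the scatter, so the two compounds cannot be told apart on this read-out. Within the data shown here, the one measured change, a shift of the methyl group around the phenyl ring, thus left the number essentially where it was.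

Compound 3 `COc1cccc(/C=C/c2nnc(-c3ccc4c(c3)OCCO4)o2)c1` has not yet been measured. It differs from compound 1 in one place: 3-methoxyphenyl in place of 4-methylphenyl on a double-bonded chain carbon bound to a double-bonded chain carbon. Among the measured compounds shown here, the only measured step that bears on this change is the one from compound 1 to compound 2, which also alters the substituent on the same phenyl ring and was within the scatter. With nothing in the data pointing in either direction, the expected step in this assay is none beyond the scatter. Compound 3 is therefore estimated to give 42000 nM, within a range from 18000 nM to 95000 nM. This estimate corresponds to an expected step of a 1.1-fold lower number from compound 1 to compound 3 (0.03 log units; within the scatter).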

Compound 3, half-maximal inhibitory concentration: > 50000 nM
Compound 3: a limit, no number; the forecaster's own chance of this, stated with the estimate: 15%; middle value at least 1.1-fold (0.07 log units) away from the limit.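

In this assay compound 3 gives > 50000 nM, which is a limit of the assay and not a number. Replacing a methylphenyl group with 3-methoxyphenyl gives an at least 1.1-fold higher number from compound 1 to compound 3 (0.04 log units; that floor lies within the scatter), and an at least 1.2-fold higher number from compound 2 to compound 3 (0.09 log units; that floor lies within the scatter); these are only floors, so the true gap could lie inside the scatter or well beyond it. The earlier step only moved a methyl group around the phenyl ring, whereas this change brings in a group with one hydrogen-bond acceptor where 4-methylphenyl has none, and it yields no lower number at this place on the chain, though the result is bounded by a single reading: the limit of > 50000 nM in this assay, at which 1 of the 3 values shown sits.

The change from 4-methylphenyl to 3-methoxyphenyl alters both the group and where it sits on the ring, and the compounds shown cannot separate those two effects. Whether an amine or a carboxylic acid on this phenyl ring would bring the number clearly down also stays open, as all the compounds shown carry only a methyl or methoxy group there.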